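The source may report more compounds than this note shows. Statements on the series, on what has been measured and on what is new or still open speak of the compounds shown alone.

Working notes on the series, values from a functional assay (aorta) for inhibition, with Oryctolagus cuniculus as the target; on this read-out lower numbers stand for stronger inhibition and higher numbers for weaker inhibition:

- compound 1 `CCOC(=O)C1=C(C)N=C(S)NC1c1cccc([N+](=O)[O-])c1`: > 1000 nM (a limit, not a number)
- compound 2 `CC1=NC(=S)N(C(=O)OC2CCN(Cc3ccccc3)CC2)C(c2ccccc2Cl)/C1=C(\O)OC(C)C`: 5 nM
- compound 3 `CC1=C(C(=O)OC(C)C)C(c2ccccc2C(F)(F)F)N(C(=O)O[C@H]2CCN(Cc3ccccc3)C2)C(=O)N1`: 790 nM

Only compound 2 and compound 3 carry true numbers here. Compound 3 has the higher number, at 790 nM against compound 2 at 5 nM, a gap well beyond the scatter. Compound 2 and compound 3 differ in more than one place, so this gap cannot be assigned to any single change.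

The next compound to read is compound 4 `CC1=C(C(=O)OC(C)C)C(c2ccccc2C(F)(F)F)N(C(=O)O[C@@H]2CCN(Cc3ccccc3)C2)C(=O)N1`, the stereo partner of compound 3. The change is the two compounds have the same atoms and bonds; at least one stereo element is drawn with a configuration in one of them and without one in the other: 1 of 2 stereo elements differ; a stereocentre at a saturated ring carbon is drawn S in compound 3 and R in compound 4. The atoms and bonds stay the same, and only the configuration at the saturated ring carbon is reversed.

Among the measured compounds shown here, no measured pair isolates a stereocentre, so the size of this step rests on judgement alone. In this assay a modest move to a lower number is expected, with a step in the opposite direction not excluded. Compound 3 stands at 790 nM, with ample room downward. The expected change is a 2.3-fold lower number from compound 3 to compound 4 (0.35 log units; beyond the scatter). For compound 4 the estimated value is 350 nM. The estimated range runs from 30 nM to 2500 nM.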

Compound 4, half-maximal inhibitory concentration: 360 nM
The estimate for compound 4 lay 1.0-fold (0.01 log units) below the measured number; measured number inside the range.
By their numbers in this assay, from the lowest: compound 2; then compound 4; then compound 3. At a limit, above all of these: compound 1.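

In this assay, this pair gives the series its first step that isolates a stereocentre, since the atoms and bonds stay the same and only the configuration at the saturated ring carbon is reversed: a 2.2-fold lower number from compound 3 to compound 4 (0.34 log units; beyond the scatter). Configuration at this carbon therefore registers in the read-out on its own, and the R form, compound 4, carries the lower number, though the step is modest and does not by itself establish a general preference for that configuration. The step should be read with one caution about how the pair is drawn: the fact that one of compounds 3 and 4 is drawn with a defined configuration and the other without, at the place where they differ

The compounds shown leave open whether a step of this size and direction would persist with a different group on the amine, such as a phenethyl group in place of the benzyl group, or with a nitrile in place of the trifluoromethyl group. They also give no basis for saying why reversing this configuration lowers the number, and a pair differing only at the second stereo element would be needed to show how much that element contributes.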